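Swapping Thiophene for Phenyl on an Acyl Sulfonamide

The source may hold more compounds than are shown below. What is called first, only, known or untested is meant among the compounds shown, and "the series" means these compounds.

Measured so far:
Compound 1 `CC(=O)c1ccc(-c2ccc(OCc3cc(C(=O)O)oc3C)cc2)cc1` in an assay on cells for displacement of a labelled ligand from prostaglandin E2 receptor EP4 subtype (Homo sapiens), read by scintillation counting (on this read-out lower numbers stand for stronger inhibition and higher numbers for weaker inhibition), gives 150 nM.
Compound 2 `COc1ccc(-c2ccc(OCc3cc(C(=O)NS(=O)(=O)c4cccs4)oc3C)cc2)cc1` in this assay gives 3.6 nM.

Of the two numbers, compound 2 has the lower one. Compound 1, which carries a plain carboxylic acid and an acetyl group where compound 2 has an acyl sulfonamide and a methoxy group, shows a much higher number, a gap well beyond the scatter. Among the compounds with values here, no single-point step between these two is available, so only the two values themselves can be compared.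

Compound 3 `COc1ccc(-c2ccc(OCc3cc(C(=O)NS(=O)(=O)c4ccccc4)oc3C)cc2)cc1` is the next compound and differs from compound 2 in one place: phenyl in place of thiophen-2-yl on a sulfonyl sulfur. The ring that leaves and the ring that enters are both flat aromatic rings attached to the same sulfonyl sulfur. Within the data shown here, no measured step of this kind exists in the set. The change is expected to be small, with no shift beyond the scatter in either direction, so for compound 3 in this assay the expected value is 4.5 nM, within 1.5 nM to 13 nM, an estimated step of a 1.3-fold higher number from compound 2 to compound 3 (0.10 log units; within the scatter) from compound 2.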

Compound 3, inhibition constant: 5 nM
Compound 3: the middle estimate sits 1.1-fold (0.05 log units) below what was measured; measured number inside the range.
By their numbers in this assay, from the lowest: compounds 2 and 3 (each within the scatter of the next); then compound 1.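

In this assay, the step of a 1.4-fold higher number from compound 2 to compound 3 (0.14 log units; within the scatter) lies within the scatter, so phenyl and thiophen-2-yl on the sulfonyl sulfur cannot be told apart. Within the data shown here, this is the first comparison in the set that changes only one place, and it shows that a six-membered ring of carbon only can stand in for a five-membered ring holding sulfur without a measurable change. Nothing measured here says why the two rings give such similar results.

As far as these compounds go, it remains open whether groups of a different kind on the sulfonyl sulfur, such as a methyl group or a phenyl ring carrying an amine, would also leave the number unchanged. From the compounds shown here alone, compound 1 differs from compound 2 in two places, so the separate contributions of its carboxylic acid and its acetyl group also remain open.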